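This account rests on a few compounds, and the source may have more. Where it says the series, first, only, none or still open, it means among the compounds named here.

Measured so far:
- compound 1 `COc1cc(-c2nn(-c3cccc(NC(=O)Nc4ccc(Cl)c(Cl)c4)c3)cc2-c2ccncc2)ccc1Cl`: 820 nM
- compound 2 `O=C(Nc1cccc(-n2cc(-c3ccncc3)c(-c3ccc(Cl)c(O)c3)n2)c1)Nc1ccc(Cl)c(Cl)c1`: 1510 nM

In a functional assay on U-251 cells (Homo sapiens) for inhibition, read by sulforhodamine B assay, with a stated time of 48 h (on this read-out higher numbers stand for weaker inhibition of growth and lower numbers for stronger inhibition of growth), compound 1 gives 820 nM, the lowest of the two numbers; the nearest is compound 2, with a 1.8-fold higher number from compound 1 to compound 2 (0.27 log units; within the scatter). Compound 3 `COc1cc(-c2nn(-c3cccc(NC(=O)c4ccc(Cl)c(C(F)(F)F)c4)c3)cc2-c2ccncc2)ccc1Cl` differs from compound 1 in 4-chloro-3-(trifluoromethyl)phenyl in place of (3,4-dichlorophenyl)amino on a carbonyl carbon. For the measured compounds named here, no measured step touches this position: the single step, a 1.8-fold higher number from compound 1 to compound 2 (0.27 log units; within the scatter), concerns the other end of the shared core. Nothing therefore points to a step beyond the scatter in this assay, and the range is kept wide. Compound 3 is expected near 1000 nM (range 250 nM to 4000 nM), which means an estimated 1.2-fold higher number from compound 1 to compound 3 (0.09 log units; within the scatter).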

Compound 3, concentration for 50% growth inhibition: 3100 nM
Beside the measured number, compound 3's estimate is 3.1-fold (0.49 log units) below it, and the stated range covers the measured number.
By their numbers in this assay, from the lowest: compounds 1 and 2 (each within the scatter of the next); then compound 3.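

For the compounds shown here, the carbonyl carbon position responds in this assay: 4-chloro-3-(trifluoromethyl)phenyl in place of (3,4-dichlorophenyl)amino gives a 3.8-fold higher number from compound 1 to compound 3 (0.58 log units; beyond the scatter), the only step so far beyond the scatter, and it runs towards weaker inhibition of growth. This single exchange removes the hydrogen-bond donor of the leaving group and changes the ring's substituents together, so the two changes cannot be separated. No supporting measurement accounts for the step.

Still open, from the compounds shown here alone, is which of these two changes carries the step. Also open, going by these compounds, is how a benzylamino group or a piperidine on this carbonyl carbon would read.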